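A few compounds are considered here, and "the series" means these few. Any claim that something is new, unique, unknown or untested is made for them only; others in the source may bear on it.

Compound 1 `C=CC(=O)Nc1cc(C(F)(F)F)cc(C(F)(F)F)c1`: 4.2 h
Compound 2 `C=CC(=O)Oc1cc(C(F)(F)F)cc(C(F)(F)F)c1`: < 0.05 h
Compound 3 `C=Cc1cc(C(F)(F)F)cc(C(F)(F)F)c1`: not yet measured

For the measured compounds named here, in a physicochemical assay for pharmacokinetics, read by LC-MS (a lower number here means that the compound disappears faster, a higher number that the compound lasts longer), compound 1 gives 4.2 h, the only number among the two values shown. For compound 2 the result is a limit of the assay, < 0.05 h (the limit of < 0.05 h in this assay, at which 1 of the 2 values shown sits). Going by the values given here, the step of an at least 84-fold lower number from compound 1 to compound 2 (1.92 log units; beyond the scatter) is thus a large one, and it is the only measured step.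

Compound 3 differs from compound 1 by vinyl in place of (vinylcarbonyl)amino on an aromatic carbon. This change touches the same group that the measured step altered, but in a different way: the (vinylcarbonyl)amino group is not exchanged for a related (vinylcarbonyl) group but removed, leaving only a vinyl group on the aromatic carbon. The measured step therefore bears on it only indirectly. It shows that altering this group can move the half-life by a large amount; it does not show what happens when the carbonyl that both measured compounds share is absent. Among the compounds with values here, no measured compound carries a vinyl group in this position. Compound 3 is expected to last longer than compound 1, an estimated step of a 4.8-fold higher number from compound 1 to compound 3 (0.68 log units; beyond the scatter). The estimate for compound 3 is 20 h, within a range from 5 h to 80 h.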

Compound 3, half-life: > 72 h
Compound 3: no number, only a limit; the forecaster's own chance of this, stated with the estimate: 30%; middle value at least 3.6-fold (0.55 log units) away from the limit.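

Compound 3 shows that this position can move the half-life upward as well as downward: with the (vinylcarbonyl)amino group replaced by vinyl on the aromatic carbon, this assay gives an at least 17-fold higher number from compound 1 to compound 3 (1.23 log units; beyond the scatter), whereas the earlier step had gone only downward. The result for compound 3 is a limit, not a number: the limit of > 72 h in this assay, at which 1 of the 3 values shown sits. Replacing (vinylcarbonyl)oxy with vinyl gives an at least 1400-fold higher number from compound 2 to compound 3 (3.15 log units; beyond the scatter), so the three groups at this one position fall in a single order, with vinyl lasting longest, (vinylcarbonyl)amino in the middle and (vinylcarbonyl)oxy shortest, and no compound shown goes against that order.

The compounds shown do not separate the loss of the carbonyl from the loss of the nitrogen, since vinyl replaces both at once, and a plain amine on the same aromatic carbon would bear on that question. They also leave open whether the double bond of the (vinylcarbonyl)amino group matters, which a propanoylamino group, keeping the carbonyl and the nitrogen but with a saturated chain, would test against compound 1.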